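Compound 3 to compound 4: butyl to benzyl

This account rests on a few compounds, and the source may have more. Where it says the series, first, only, none or still open, it means among the compounds named here.

In a functional assay on A549 cells (Homo sapiens) for antiproliferative activity, read by MTT assay, with a stated time of 48 h (on this read-out higher numbers stand for weaker inhibition and lower numbers for stronger inhibition), compound 3 (`CCCCC1(O)C(=O)Nc2ccc(Nc3ccc(F)cc3)cc21`) gives 6500 nM. Compound 2 (`CCCCC1(O)C(=O)Nc2ccc(Nc3ccc(C)cc3)cc21`) gives 7500 nM, within the scatter of compound 3, while compound 1 (`CCCCCCC1(O)C(=O)Nc2ccc(Nc3ccc(OC)cc3)cc21`) stands higher at 18600 nM. Compound 4 (`O=C1Nc2ccc(Nc3ccc(F)cc3)cc2C1(O)Cc1ccccc1`) has phenyl in place of propyl on a saturated chain carbon bound to a saturated ring carbon. Among the compounds with values here, the only measured step, a 1.2-fold lower number from compound 2 to compound 3 (0.06 log units; within the scatter), lies within the scatter and concerns an aromatic carbon, so it bears only indirectly. Within the data shown here, compound 1 differs from compound 3 in more than one place, and no measured step isolates this change. With no evidence for a shift, the expected step is a 1.1-fold lower number from compound 3 to compound 4 (0.03 log units; within the scatter), within the scatter. Compound 4 is expected at 6000 nM, with an estimated range of 2500 nM to 14000 nM.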

Compound 4, half-maximal inhibitory concentration: 3000 nM
Estimate against measurement, compound 4: 2.0-fold (0.30 log units) above; measured number inside the range.
By their numbers in this assay, from the lowest: compound 4; then compounds 3 and 2 (each within the scatter of the next); then compound 1.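

Phenyl in place of propyl on a saturated chain carbon bound to a saturated ring carbon gives a 2.2-fold lower number from compound 3 to compound 4 (0.34 log units; beyond the scatter) in this assay. This position therefore responds to the group it carries, and a six-membered aromatic ring is accepted there in place of a ring-free chain. Nothing measured here accounts for the step.

Open, on these data alone, is whether cyclohexylmethyl would give the same step as benzyl, which would separate aromatic character from ring size. Also open, as far as these compounds go, is how phenethyl, or benzyl carrying an amine or a carboxylic acid, would read.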